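The compounds below may be only part of what the source reports. "The series", "measured", "known", "first", "only" and "open" are said of these compounds alone.

Compound 1 `COc1ccc(N(C)c2ccnc(Cl)n2)cc1F` is the starting point. In a functional assay on HeLa cells (Homo sapiens) for antiproliferative activity, read by MTT assay, with a stated time of 48 h (a lower number here means a stronger inhibitor, a higher number a weaker inhibitor), compound 1 gives 241 nM. Compound 2 `COc1ccc(N(C)c2ccnc(Cl)n2)cc1Cl` differs from it in one spot: chloro in place of fluoro on an aromatic carbon. In this assay compound 2 gives 517 nM, and the step of a 2.1-fold higher number from compound 1 to compound 2 (0.33 log units; beyond the scatter) is the only measured effect of this swap in the set.

Compound 3 `COc1ccc(N(C)c2cc(C)nc(C)n2)cc1F` carries a different core; the difference between the two cores is not broken down here. In this assay compound 3 gives 471 nM, which sits within the scatter of both compound 1 and compound 2, so no ordering among them is claimed.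

Compound 4 `COc1ccc(N(C)c2cc(C)nc(C)n2)cc1Cl` repeats the halogen swap on the core of compound 3: chloro in place of fluoro on an aromatic carbon. The surroundings are described a little differently, meta to a large group here against meta to a group of 9 heavy atoms in compound 2, so it is the same kind of change rather than the same change. For the measured compounds named here, only one earlier example exists, so the expectation rests on a single step. Because compound 1 moved by a 2.1-fold higher number from compound 1 to compound 2 (0.33 log units; beyond the scatter), compound 4 is expected to shift by about a 2.0-fold higher number from compound 3 to compound 4 (0.30 log units; within the scatter) relative to compound 3. Compound 4 is therefore estimated at 950 nM, with a plausible range from 420 nM to 2100 nM.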

Compound 4, half-maximal inhibitory concentration: 316 nM
Compound 4: middle estimate off by 3.0-fold (0.48 log units), on the high side, and the stated range ends above it.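

On the core of compound 3, chloro in place of fluoro gives a 1.5-fold lower number from compound 3 to compound 4 (0.17 log units; within the scatter) in this assay, so the two compounds of this pair cannot be told apart in this measurement. Set beside the first example, the swap does not carry over as a fixed shift from one core to the other: the same change on two cores in this assay, a 2.1-fold higher number (0.33 log units; beyond the scatter) from compound 1 to compound 2 and a 1.5-fold lower number (0.17 log units; within the scatter) from compound 3 to compound 4, 3.2-fold (0.50 log units) apart, beyond the scatter of two such steps

This shows that, in these two pairs, the result of the swap on one core does not predict its result on the other, but two pairs are too few to give a rule, and they do not show why the steps differ or what the swap would do on a further core.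

The compounds shown carry only fluoro or chloro at this place, so it stays open how a bromo or a methyl group would behave there on either core. Also open, as far as these compounds go, is what an amine in place of the chloro group on the core of compound 1, or a longer chain such as ethoxy in place of the methoxy group, would do in this assay.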